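The source may report more compounds than this note shows. Statements on the series, on what has been measured and on what is new or still open speak of the compounds shown alone.

Measured compounds:
- compound 1 `COc1ccc(/C(=C/CCCCC(=O)O)c2cccnc2)cc1`: 80 nM
- compound 2 `O=C(O)C(CCC/C=C(\c1ccccc1)c1cccnc1)C1=CCCC1`: 60 nM
- compound 3 `CC(C)(CCCC/C=C(/c1ccccc1)c1cccnc1)C(=O)O`: 38 nM

All three were tested in an assay (Equus caballus) for inhibition of Thromboxane-A synthase (Homo sapiens), using microsomes; on this read-out lower numbers stand for stronger inhibition and higher numbers for weaker inhibition. Compound 2 gives 60 nM there, which is the second highest of the three numbers. Its nearest neighbour is compound 1 with 80 nM, and the number furthest from it belongs to compound 3 with 38 nM; both of those gaps stay within the scatter of repeated measurements, so the three compounds cannot be ranked against each other on these data.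

Compound 4 `O=C(O)C(CCC/C=C(\c1ccccc1)c1cccnc1)C1(O)CCCC1` has not yet been measured in this assay. Compared with compound 2, the change is 1-hydroxycyclopentyl in place of cyclopent-1-en-1-yl on a saturated chain carbon bound to a carbonyl carbon and a saturated chain carbon. The hydroxyl-bearing saturated ring replaces the unsaturated ring at the same place on the chain. For the measured compounds named here, no pair of measured compounds shows what this kind of change does, and there is no measured step to lean on. Given that the three measured values all sit close together, the step from compound 2 to compound 4 is expected to be small, a 1.2-fold higher number from compound 2 to compound 4 (0.07 log units; within the scatter), with no clear direction beyond the scatter. Compound 4 is therefore estimated at 70 nM in this assay, within a range of 25 nM to 200 nM.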

Compound 4, half-maximal inhibitory concentration: 65 nM
Compound 4: middle estimate off by 1.1-fold (0.03 log units), on the high side, within the range that was stated.
By their numbers in this assay, from the lowest: compounds 3, 2, 4 and 1 (each within the scatter of the next, the first and the last beyond it).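

In this assay, the position on a saturated chain carbon bound to a carbonyl carbon and a saturated chain carbon now has its first measured step: 1-hydroxycyclopentyl in place of cyclopent-1-en-1-yl gives a 1.1-fold higher number from compound 2 to compound 4 (0.03 log units; within the scatter) and so stays inside the usual scatter. This swap takes away the double bond of the ring and brings in a hydrogen-bond donor and a hydrogen-bond acceptor, yet the read-out cannot tell the two compounds apart, so at this position and for this one pair, the change leaves no visible mark on inhibition. Nothing measured alongside this result offers an explanation for it.

The compounds shown leave open whether losing the double bond and gaining the hydroxyl each do nothing or instead offset one another, a question that a plain cyclopentyl group at this place would help to settle. They also leave open whether an amine in place of the hydroxyl, or a six-membered carbon ring in place of the five-membered one, would read the same in this assay as these two compounds do.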